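The compounds below may be only part of what the source reports. "The series", "measured", "known", "first", "only" and "open" are said of these compounds alone.

In a functional assay on A549 cells (Homo sapiens) for inhibition, read by MTT assay, with a stated time of 72 h (on this read-out higher numbers stand for weaker inhibition and lower numbers for stronger inhibition), compound 1 `COc1ccccc1-c1csc2cnc(Nc3ccc(NC(=O)[C@@H]4CCCNC4)cc3)nc12` gives 410 nM, the lowest number among the three measured compounds. Compound 3 `COc1ccccc1-c1csc2cnc(Nc3ccc(C(=O)NCC4CCNCC4)c(F)c3)nc12` gives 3410 nM and compound 2 `COc1ccccc1-c1csc2cnc(Nc3cc(F)c(C(=O)NC4CCNCC4)cc3F)nc12` gives 5390 nM; both numbers lie higher than that of compound 1, beyond the scatter. Compound 4 `COc1ccccc1-c1csc2cnc(Nc3ccc(C(=O)NC4CCNCC4)cc3)nc12` remains unmeasured. It keeps the core of compound 1 and changes one group: (piperidin-4-yl)carbamoyl in place of ((piperidin-3-yl)carbonyl)amino on an aromatic carbon. Within the data shown here, no two measured compounds differ in one place only, so this step has no direct precedent. The nearest guide is compound 2, which carries the same (piperidin-4-yl)carbamoyl group on a fluorinated ring and gives 5390 nM. Compound 3, also a carbamoyl compound with fluorine on the ring, gives 3410 nM. Compound 4 lacks that fluorine, so it is expected to sit somewhat lower than these two, but still well above compound 1. The expected step is a 4.9-fold higher number from compound 1 to compound 4 (0.69 log units; beyond the scatter), toward weaker inhibition and beyond the scatter. For compound 4 the estimated value is 2000 nM, with an expected range from 700 nM to 5500 nM.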

Compound 4, half-maximal inhibitory concentration: 360 nM
For compound 4 the middle estimate is 5.6-fold (0.74 log units) above the measured one; the measured number lies below the stated range.
By their numbers in this assay, from the lowest: compounds 4 and 1 (each within the scatter of the next); then compounds 3 and 2 (each within the scatter of the next).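

In this assay, placing (piperidin-4-yl)carbamoyl in place of ((piperidin-3-yl)carbonyl)amino, on the aromatic carbon para to a large group, gives a 1.1-fold lower number from compound 1 to compound 4 (0.06 log units; within the scatter) and so leaves the two compounds indistinguishable on this read-out. At this position, the same atoms can therefore be joined differently, and the defined stereocentre of compound 1 given up, without a step beyond the scatter. No supporting measurement bears on why these two compounds read alike.

The amide direction and the piperidine attachment point change together in this step, so their separate contributions remain unresolved. Also open, going by these compounds, is how this position would respond to a group without the piperidine ring, such as a simple aminomethyl group, a carboxylic acid or a longer aminoalkyl chain.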